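This account rests on a few compounds, and the source may have more. Where it says the series, first, only, none or still open, it means among the compounds named here.

Of the compounds shown here, three built on one shared core have so far been tested in a functional assay on P388 cells (Mus musculus) for cytotoxicity; a lower number here means a stronger inhibitor, a higher number a weaker inhibitor. Compound 1 `CC/C=C/C(CC)CC(C)CC1(CC)C=C(CC)C(CC(=O)O)OO1` gives 0.3 ug/mL. Compound 2 `CC/C=C/C(CC)CC(C)CC1(CC)C=C(CC)C(CC(=O)OC)OO1` gives 0.9 ug/mL in this assay. Compound 3 `CCCCC(CC)CC(C)CC1(CC)C=C(CC)C(CC(=O)O)OO1` gives 0.2 ug/mL in this assay. Compound 3 thus holds the lowest of the three numbers, yet the step of a 1.5-fold lower number from compound 1 to compound 3 (0.18 log units; within the scatter) lies within the scatter, so compound 3 and compound 1 cannot be told apart on these numbers; only the gap between compound 3 and compound 2 is beyond the scatter.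

The next compound, compound 4 `CCCCC(CC)CC(C)CC1(CC)C=C(CC)C(CC(=O)OC)OO1`, differs from compound 3 in a single place: methyl in place of hydrogen on an oxygen next to a carbonyl group. The same change has been made once before in this series, in the step of a 3.0-fold higher number from compound 1 to compound 2 (0.48 log units; beyond the scatter), where it produced a modest rise in the number. The step of a 1.5-fold lower number from compound 1 to compound 3 (0.18 log units; within the scatter) shows that the other point at which compound 3 differs from compound 1 makes little difference on its own, so that earlier step is the best guide here. For compound 4 a rise of similar size is therefore expected, a 3.0-fold higher number from compound 3 to compound 4 (0.48 log units; beyond the scatter). The estimate for compound 4 in this assay is 0.6 ug/mL, with a range from 0.3 ug/mL to 1.2 ug/mL.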

Compound 4, half-maximal inhibitory concentration: 0.2 ug/mL
Compound 4: middle estimate off by 3.0-fold (0.48 log units), on the high side, outside the stated range (below it).
By their numbers in this assay, from the lowest: compounds 3, 4 and 1 (each within the scatter of the next); then compound 2.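

Placing methyl on the oxygen next to a carbonyl group, which turns carboxy into methoxycarbonyl, has no fixed effect in this assay. With the butyl chain in place the result is no change at the digits printed from compound 3 to compound 4 (within the scatter), so the rise seen with the but-1-en-1-yl chain does not carry over, and the outcome of this change depends on the rest of the molecule: the same change on two cores in this assay, a 3.0-fold higher number (0.48 log units; beyond the scatter) from compound 1 to compound 2 and no change at the digits printed (within the scatter) from compound 3 to compound 4, 3.0-fold (0.48 log units) apart, beyond the scatter of two such steps

The swap of but-1-en-1-yl for butyl, which could not be detected among the carboxy compounds, does register among the methoxycarbonyl compounds, with a 4.5-fold lower number from compound 2 to compound 4 (0.65 log units; beyond the scatter), so it too depends on its partner group: the same change on two cores in this assay, a 1.5-fold lower number (0.18 log units; within the scatter) from compound 1 to compound 3 and a 4.5-fold lower number (0.65 log units; beyond the scatter) from compound 2 to compound 4, 3.0-fold (0.48 log units) apart, beyond the scatter of two such steps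

Of these compounds, only compound 2 combines methoxycarbonyl with the but-1-en-1-yl chain, and its number is set apart from those of its single-change neighbours, compound 1 and compound 4.

The compounds shown leave open whether a larger ester such as ethoxycarbonyl, or an amide in place of methoxycarbonyl, would behave like compound 4 or like compound 2. They also leave open whether a longer chain such as hexyl in place of butyl would keep the methyl change as silent as it is here.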